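A few compounds are considered here, and "the series" means these few. Any claim that something is new, unique, unknown or untested is made for them only; others in the source may bear on it.

Of the compounds shown here, three with a shared core have been measured so far in a functional assay on MCF7 cells (Homo sapiens) for antiproliferative activity, read by MTT assay, with stated times of 24 h and 72 h (a higher number here means a weaker inhibitor, a lower number a stronger inhibitor), of this series. Here compound 2 (`COc1cc(N2C(=O)[C@@H](Oc3ccccc3)[C@H]2c2ccc3ccccc3c2)cc(OC)c1OC`) gives 282000 nM and sits at the high end of the numbers. Compound 1 (`COc1cc(N2C(=O)[C@H](Oc3ccccc3)[C@H]2c2ccc(C#N)cc2)cc(OC)c1OC`) gives 168000 nM in the same test, within the scatter of compound 2, while compound 3 (`COc1ccc([C@@H]2[C@@H](Oc3ccccc3)C(=O)N2c2cc(OC)c(OC)c(OC)c2)cc1[N+](=O)[O-]`) gives a much lower 4100 nM by comparison.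

Compound 4 (`COc1cc(N2C(=O)[C@@H](Oc3ccccc3)[C@H]2c2ccc([S+](C)[O-])cc2)cc(OC)c1OC`) has not yet been measured. Its change from compound 2 falls on a saturated ring carbon: a group of 9 heavy atoms (7 carbon, 1 oxygen, 1 sulfur; one six-membered aromatic ring of carbon only) in place of a group of 10 heavy atoms (10 carbon; 2 six-membered aromatic rings of carbon only), on a saturated ring carbon is the whole difference. Going by the values given here, one measured step bears on this place, a 41-fold lower number from compound 1 to compound 3 (1.61 log units; beyond the scatter) with 4-methoxy-3-nitrophenyl in place of 4-cyanophenyl. It is a large step, beyond the scatter, so a swap at this carbon can move the number a long way. Yet compound 1 and compound 2 carry different groups here and still lie within the scatter of each other. Among the compounds with values here, no measured compound carries the group that enters in compound 4, so only a moderate move towards a lower number is expected. The estimated change is a 3.5-fold lower number from compound 2 to compound 4 (0.55 log units; beyond the scatter) and it remains quite uncertain. For compound 4 the expected value is 80000 nM with an estimated range from 12000 nM to 300000 nM in this assay once measured.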

Compound 4, half-maximal inhibitory concentration: 20000 nM
Compound 4: the middle estimate sits 4.0-fold (0.60 log units) above what was measured; the range from low to high includes it.
By their numbers in this assay, from the lowest: compound 3; then compound 4; then compounds 1 and 2 (each within the scatter of the next).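

In this assay, the change at this saturated ring carbon gives a 14-fold lower number from compound 2 to compound 4 (1.15 log units; beyond the scatter), so a second large step now stands at this position, and this one starts from naphthalen-2-yl rather than from a single substituted phenyl ring. The earlier compounds shown here placed naphthalen-2-yl only within the scatter of 4-cyanophenyl, leaving the 4-methoxy-3-nitrophenyl group as the only one tied to a much lower number; the new step shows that a group carrying neither the methoxy nor the nitro substituent can also lower the number well beyond the scatter. No measurement shown here explains why this swap moves the number so far, and the step alone cannot separate the loss of the second aromatic ring from the arrival of the sulfur and oxygen atoms. On these data alone, what remains open is how much of the step belongs to the sulfur-bearing substituent, since an unsubstituted phenyl ring at this carbon would be needed to tell the two parts apart. As far as these compounds go, it is also open how a sulfone, an amine or a carboxylic acid on that aromatic ring would compare, and whether the step holds when the phenoxy group on the neighbouring ring atom is replaced by another group.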